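The compounds below may be only part of what the source reports. "The series", "measured", "known", "first", "only" and "open" are said of these compounds alone.

Compound 1 `Cc1cccc(CNC(=O)c2nn(-c3ccc(F)cc3)c(OC[C@@H](O)C[C@@H](O)CC(=O)O)c2C(C)C)c1` gives 280 nM in a functional assay on L6 cells (Rattus norvegicus) for inhibition (on this read-out higher numbers stand for weaker inhibition and lower numbers for stronger inhibition), the lowest number among the two compounds measured there. Compound 2 `CC(C)c1c(C(=O)N2CCCCC2)nn(-c2ccc(F)cc2)c1OC[C@@H](O)C[C@@H](O)CC(=O)O` gives 32200 nM, and compound 3 `COc1ccccc1CNC(=O)c1nn(-c2ccc(F)cc2)c(OC[C@@H](O)C[C@@H](O)CC(=O)O)c1C(C)C` has "not determined" (no result reported) in this assay, so no result is available for it. Compound 4 `COc1cccc(CN(C)C(=O)c2nn(-c3ccc(F)cc3)c(OC[C@@H](O)C[C@@H](O)CC(=O)O)c2C(C)C)c1` differs from compound 1 as follows: (3-methoxybenzyl)(methyl)amino in place of (3-methylbenzyl)amino on a carbonyl carbon. Going by the values given here, the only measured step that bears on this change is a 120-fold higher number from compound 1 to compound 2 (2.06 log units; beyond the scatter), where the amide hydrogen was lost together with the benzyl group. Compound 4 also loses that hydrogen but keeps a benzyl group, so a clear weakening is expected, though smaller than that step. The expected outcome for compound 4 is 2500 nM, within 500 nM to 15000 nM, a step of an 8.9-fold higher number from compound 1 to compound 4 (0.95 log units; beyond the scatter).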

Compound 4, half-maximal inhibitory concentration: 9460 nM
Estimate against measurement, compound 4: 3.8-fold (0.58 log units) below; low and high end bracket the measured number.
By their numbers in this assay, from the lowest: compound 1; then compound 4; then compound 2.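

On the carbonyl carbon, (3-methoxybenzyl)(methyl)amino gives up much of the inhibition seen with (3-methylbenzyl)amino in this assay, with a 34-fold higher number from compound 1 to compound 4 (1.53 log units; beyond the scatter) as the cost. It still does better than piperidin-1-yl, with a 3.4-fold lower number from compound 2 to compound 4 (0.53 log units; beyond the scatter) in the same assay, so a benzyl group without the amide hydrogen recovers only part of the loss. Nothing measured here explains either step. This single change swaps three features at once: the amide hydrogen, the added methyl and the methoxy in place of methyl. Going by these compounds, the effect of each remains open, and (3-methoxybenzyl)amino or (3-methylbenzyl)(methyl)amino would help separate them.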